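Notes on a side-chain change from compound 2

This account rests on a few compounds, and the source may have more. Where it says the series, first, only, none or still open, it means among the compounds named here.

Of the compounds shown here, two have numbers so far in an ADME assay on HeLa cells (Homo sapiens) for cytotoxicity, with a stated time of 72 h; on this read-out higher numbers stand for lower toxicity in this test and lower numbers for higher toxicity in this test. Compound 2 `COc1ccc(/C=C\c2cc(OC)c(OC)c(OC)c2)cc1NC(=O)CNC(=O)[C@H](CCCNC(=N)N)NC(=O)[C@H](CCCNC(=N)N)NC(=O)c1ccccc1` gives 7.2 nM, the lower of the two, and compound 1 `COc1ccc(/C=C\c2cc(OC)c(OC)c(OC)c2)cc1NC(=O)[C@H](CO)NC(=O)[C@H](CCCNC(=N)N)NC(=O)[C@H](CCCCN)NC(=O)c1ccccc1` gives 61.8 nM, a gap beyond the scatter. Within the data shown here, these two compounds differ in more than one place, so the gap belongs to no single change, and no measured single-change step is available as a guide.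

Compound 3 `COc1ccc(/C=C\c2cc(OC)c(OC)c(OC)c2)cc1NC(=O)CNC(=O)[C@H](CCCNC(=N)N)NC(=O)[C@H](CCCCN)NC(=O)c1ccccc1` departs from compound 2 at one place: a group of 2 heavy atoms (1 carbon, 1 nitrogen; no ring) in place of a group of 4 heavy atoms (1 carbon, 3 nitrogen; no ring), on a saturated chain carbon, four bonds along the chain from an amide-type nitrogen and a carbonyl carbon. The entering group is aminomethyl.

The only reference for the direction is thin. Among the measured compounds shown here, with compound 1 at 61.8 nM as the one measured number higher than that of compound 2, a moderate rise in this assay is expected, which would mean lower toxicity in this test, and a result within the scatter of compound 2 remains possible. The estimated size is a 2.8-fold higher number from compound 2 to compound 3 (0.44 log units; beyond the scatter). For compound 3 the expected value is 20 nM, with an estimated range of 7 nM to 60 nM.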

Compound 3, half-maximal cytotoxic concentration: 78.2 nM
Beside the measured number, compound 3's estimate is 3.9-fold (0.59 log units) below it, outside the stated range (above it).
By their numbers in this assay, from the lowest: compound 2; then compounds 1 and 3 (each within the scatter of the next).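

In this assay, among these compounds, aminomethyl in place of the group of 4 heavy atoms (1 carbon, 3 nitrogen; no ring), on a saturated chain carbon, four bonds along the chain from an amide-type nitrogen and a carbonyl carbon, gives the first single-place reading at this position (an 11-fold higher number from compound 2 to compound 3 (1.04 log units; beyond the scatter)), which stands for lower toxicity in this test. At the other place, hydrogen in place of hydroxymethyl on a saturated chain carbon bound to an amide-type nitrogen and a carbonyl carbon gives a step within the scatter (a 1.3-fold higher number from compound 1 to compound 3 (0.10 log units; within the scatter)), so this change has no readable effect in this test. No measurement at hand bears on the reason for the large side-chain step.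

With one replacement at this position, the compounds shown do not tell whether the size of the step follows the group that leaves or aminomethyl as the group that enters. Going by these compounds, a longer chain ending in an amine, or a carboxylic acid, on the same saturated chain carbon would test that, and whether the step holds with hydroxymethyl present also remains open.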